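A few compounds are considered here, and "the series" means these few. Any claim that something is new, unique, unknown or untested is made for them only; others in the source may bear on it.

Of the compounds shown here, three share one core and have been measured in an assay for inhibition of Amine oxidase [flavin-containing] B (Mus musculus), read by fluorescence, with a stated time of 30 min, in the presence of a further agent that is not named here; a higher number here means a weaker inhibitor, a lower number a stronger inhibitor. Compound 1 `Cc1ccc(C(=O)Nc2ccc(-c3nc4c([nH]3)c(=O)n(C)c(=O)n4C)cc2)cc1` gives 13900 nM. Compound 2 `Cc1ccc(C(=O)Nc2ccc(-c3nc4c(c(=O)n(C)c(=O)n4C)n3C)cc2)cc1`, which carries a methyl in place of a hydrogen on an aromatic nitrogen, gives 11300 nM; that step, a 1.2-fold lower number from compound 1 to compound 2 (0.09 log units; within the scatter), is within the scatter. Compound 3 `Cn1c(=O)c2[nH]c(-c3cccc(NC(=O)c4ccccc4)c3)nc2n(C)c1=O` gives 18900 nM. Among the three, compound 3 has the highest number, yet its gaps to compound 1 and to compound 2 both lie within the scatter, so the three cannot be ranked.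

Compound 4 `COc1ccc(C(=O)Nc2cccc(-c3nc4c([nH]3)c(=O)n(C)c(=O)n4C)c2)cc1` has not yet been measured. It differs from compound 3 by methoxy in place of hydrogen on an aromatic carbon: a methoxy in place of a hydrogen on an aromatic carbon of a six-membered aromatic ring of carbon only, para to a large group. For the measured compounds named here, none of the measured steps touches this part of the molecule; the only step known, from compound 1 to compound 2, concerns the aromatic nitrogen and was within the scatter. There is therefore no basis in these data for expecting a shift in this assay beyond the scatter in either direction.

The expected step from compound 3 to compound 4 is a 1.2-fold lower number from compound 3 to compound 4 (0.07 log units; within the scatter). Compound 4 is estimated at 16000 nM, with a range from 6000 nM to 45000 nM.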

Compound 4, half-maximal inhibitory concentration: 16000 nM
Compound 4: the middle estimate sits on the measured number at the digits printed; the range from low to high includes it.
By their numbers in this assay, from the lowest: compounds 2, 1, 4 and 3 (each within the scatter of the next).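

For the compounds shown here, until now, the only step that could be read concerned an aromatic nitrogen of the shared core, so nothing was known about changing the benzoyl ring. In this assay, the change from phenyl to 4-methoxyphenyl amounts to a 1.2-fold lower number from compound 3 to compound 4 (0.07 log units; within the scatter), so at this position a methoxy in place of a hydrogen produces no shift that can be told apart from the ordinary spread of repeated measurements. Nothing further is available to explain why the number stays within that spread, whether for this group or for this position.

From the compounds shown here alone, one substituent at one position says little about the ring as a whole, so it remains open whether an amine, a carboxylic acid or a longer chain such as butoxy, placed here instead of methoxy, would move the number beyond the scatter. Going by these compounds, it also remains open whether a methoxy on another carbon of this ring would behave in the same way, or whether any single change to this ring can shift the number clearly in either direction.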